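The source may hold more compounds than are shown below. What is called first, only, known or untested is meant among the compounds shown, and "the series" means these compounds.

Measured compounds:
Compound 1 `CCCn1nc(C)c2c1NC(=O)CN=C2c1ccccc1Cl` — 40 mg/kg
Compound 2 `Cc1nn(C(C)C)c2c1C(c1ccccc1Cl)=NCC(=O)N2` — 20 mg/kg

For the measured compounds named here, in a functional assay on the whole organism (strain Holtzman) with Rattus norvegicus as the target (a lower number here means that less compound is needed, a higher number that more compound is needed for the effect), compound 2 holds the lowest of the two numbers, yet its only neighbour is compound 1, and the step of a 2.0-fold lower number from compound 1 to compound 2 (0.30 log units; within the scatter) lies within the scatter. Compound 3 `CCCCn1nc(C)c2c1NC(=O)CN=C2c1ccccc1Cl` differs from compound 2 by butyl in place of isopropyl on an aromatic nitrogen. Going by the values given here, the one measured step that bears on this, a change of the alkyl group on the same aromatic nitrogen, is a 2.0-fold lower number from compound 1 to compound 2 (0.30 log units; within the scatter), which did not leave the scatter. Compound 3 is therefore expected to show a 1.3-fold higher number from compound 2 to compound 3 (0.10 log units; within the scatter). For compound 3 the estimate is 25 mg/kg, with a range from 10 mg/kg to 60 mg/kg.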

Compound 3, minimum effective dose: 40 mg/kg
Estimate against measurement, compound 3: 1.6-fold (0.20 log units) below, and the stated range covers the measured number.
By their numbers in this assay, from the lowest: compounds 2, 1 and 3 (each within the scatter of the next).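

Now that butyl is included, the three alkyl groups on this aromatic nitrogen cannot be told apart in this assay. Butyl in place of isopropyl gives a 2.0-fold higher number from compound 2 to compound 3 (0.30 log units; within the scatter), and methyl in place of hydrogen on the saturated chain carbon, three bonds along the chain from the aromatic nitrogen, gives no change at the digits printed from compound 1 to compound 3 (within the scatter). Thus neither the straight-chain extension nor the exchange of isopropyl for butyl leaves the scatter. No measured evidence bears on these numbers. As far as these compounds go, whether a longer chain such as hexyl, a cyclopropyl ring or an amine at this nitrogen would move the dose beyond the scatter remains open.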